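This account rests on a few compounds, and the source may have more. Where it says the series, first, only, none or still open, it means among the compounds named here.

In a functional assay on PC-3 cells (Homo sapiens) for inhibition, read by sulforhodamine B assay (a higher number here means a weaker inhibitor of growth, a lower number a stronger inhibitor of growth), compound 1 `Oc1cccc2[nH]c(-c3ccc(-c4ccc(-c5ccccc5)cc4)cc3)nc12` gives 1240 nM. Compound 2 `Oc1cccc2[nH]c(-c3ccc(-c4ccc(-c5cccc(Cl)c5)cc4)cc3)nc12`, which carries one chloro group in place of a hydrogen, gives 2560 nM. This is the higher of the two numbers, which makes compound 2 the weaker growth inhibitor of the pair.

Compound 3 `COc1ccc(-c2ccc(-c3ccc(-c4nc5c(O)cccc5[nH]4)cc3)cc2)cc1OC` keeps the shared core but has 3,4-dimethoxyphenyl in place of 3-chlorophenyl on an aromatic carbon.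

Within the data shown here, only one measured step bears on this change, since it also alters the phenyl ring now being replaced: a 2.1-fold higher number from compound 1 to compound 2 (0.31 log units; beyond the scatter). Among the measured compounds shown here, that step is modest, and it is a poor guide to direction, since no measured compound carries a methoxy group. For the measured compounds named here, the size of that single step therefore suggests only that a change on this ring need not move the number far.

For compound 3, the estimated step in this assay is a 1.3-fold lower number from compound 2 to compound 3 (0.11 log units; within the scatter), so no clear change from compound 2 is expected. For compound 3, the expected value is 2000 nM, with an estimated range from 800 nM to 6000 nM.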

Compound 3, concentration for 50% growth inhibition: 1240 nM
The estimate for compound 3 lay 1.6-fold (0.21 log units) above the measured number; low and high end bracket the measured number.
By their numbers in this assay, from the lowest: compounds 1 and 3 (each within the scatter of the next); then compound 2.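

In this assay, replacing 3-chlorophenyl with 3,4-dimethoxyphenyl gives a 2.1-fold lower number from compound 2 to compound 3 (0.31 log units; beyond the scatter), so a substituted end ring does not always mean a weaker growth inhibitor than the plain phenyl of compound 1. Comparing the same group with phenyl gives no change at the digits printed from compound 1 to compound 3 (within the scatter), which shows that this position accepts 3,4-dimethoxyphenyl, with its 2 hydrogen-bond acceptors, with no measurable loss; among these three compounds, compound 2 is the only one that stands apart, as the weakest growth inhibitor. No measured information here explains why the chloro and dimethoxy compounds differ.

From the compounds shown here alone, it remains open whether both methoxy groups are needed for this result, or whether a single methoxy group at either place on the ring would give the same reading. Going by these compounds, the three compounds also cannot show how this position would respond to an amine or a carboxylic acid, so the range of groups accepted on this ring in this assay is still unknown.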